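Bromo to fluoro on the anilide ring of two pyridazinone cores

A few compounds are considered here, and "the series" means these few. Any claim that something is new, unique, unknown or untested is made for them only; others in the source may bear on it.

Measured so far in an assay on HL-60 cells for agonist activity at N-formyl peptide receptor 3 (Homo sapiens), read by calcium flux; on this read-out lower numbers stand for an effect already at smaller amounts and higher numbers for an effect only at larger amounts of compound:
- compound 1 `COc1cccc(Cc2cc(-c3ccccc3)nn(CC(=O)Nc3ccc(Br)cc3)c2=O)c1` gives > 50000 nM, a limit of the assay
- compound 2 `COc1cccc(Cc2cc(-c3ccccc3)nn(CC(=O)Nc3ccc(F)cc3)c2=O)c1` gives > 50000 nM, a limit of the assay
- compound 3 `Cc1cc(Cc2ccccc2)c(=O)n(CC(=O)Nc2ccc(Br)cc2)n1` gives > 50000 nM, a limit of the assay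

The change fluoro in place of bromo on an aromatic carbon gives a step that the two limits leave unreadable from compound 1 to compound 2; the step cannot be read because of the limit of > 50000 nM in this assay, at which 3 of the 3 values shown sit. The core of compound 3 differs from the core of compound 1, but that difference is not broken down here. Compound 4 `Cc1cc(Cc2ccccc2)c(=O)n(CC(=O)Nc2ccc(F)cc2)n1` carries the same change on the core of compound 3: fluoro in place of bromo on an aromatic carbon. Within the data shown here, since all three values sit at the limit, no step of any size has been read. For compound 4 the expected step is a step that the limit leaves unreadable from compound 3 to compound 4, resting on compound 3 at > 50000 nM and on the unreadable step in the pair of compound 1 and compound 2. Compound 4 is estimated at 60000 nM, most likely again reported only as a limit.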

Compound 4, half-maximal effective concentration: > 50000 nM
Compound 4 was reported as a limit (the forecaster's own chance of this, stated with the estimate: 85%); the middle value is on the limit's open side.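

No new step can be read between compound 3 and compound 4, because both values are limits of the assay: the limit of > 50000 nM in this assay, at which 4 of the 4 values shown sit.

The compounds shown leave open whether fluoro in place of bromo changes the read-out on either core.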